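The source may hold more compounds than are shown below. What is called first, only, known or untested is meant among the compounds shown, and "the series" means these compounds.

Working notes on the series. All three measured compounds share one core and differ only in the group on the amide-type nitrogen; the read-out throughout is a functional assay on the whole organism for inhibition, with Mus musculus as the target, at a dose of 30 mg/kg by the oral route; a higher number here means more inhibition at the dose given (going by the name of the read-out), a lower number less inhibition. Compound 1 `O=C(NCCCOc1ccc2nc(O)ccc2c1)N(C1CCCCC1)C1CC1` gives 100% in this assay. Compound 2 `O=C(NCCCOc1ccc2nc(O)ccc2c1)N(C1CC1)[C@@H]1CCCCC[C@H]1O` gives 44%. Compound 3 `O=C(NCCCOc1ccc2nc(O)ccc2c1)N(C1CC1)[C@H]1CC[C@H](O)CC1` gives 0%.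

Compound 3 therefore stands lowest of the three, with compound 2 nearest and compound 1 furthest, both gaps beyond the scatter. The steps read as follows: a number 56 percentage points lower from compound 1 to compound 2 (beyond the scatter); a number 100 percentage points lower from compound 1 to compound 3 (beyond the scatter); a number 44 percentage points lower from compound 2 to compound 3 (beyond the scatter).

Compound 4 `CCCCO[C@H]1CCCC[C@@H]1N(C(=O)NCCCOc1ccc2nc(O)ccc2c1)C1CC1` is the next step from compound 3. (2-butoxycyclohexyl in place of 4-hydroxycyclohexyl on an amide-type nitrogen). Going by the values given here, two measured steps bear on it. The step that introduced a hydroxy on the ring carbon, a number 100 percentage points lower from compound 1 to compound 3 (beyond the scatter), was large and downward; the step from one hydroxy-bearing ring to the other, a number 44 percentage points lower from compound 2 to compound 3 (beyond the scatter), was also large. Compound 4 reverses the hydroxy on the ring and returns to a cyclohexyl, which points to a large upward step in this assay, though no alkoxy on this ring has been measured and the ceiling of compound 1 need not be reached. Compound 4 is estimated at 65%, with a range of 25% to 100%, which means an expected step of a number 65 percentage points higher from compound 3 to compound 4 (beyond the scatter).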

Compound 4, a percentage reported as inhibition, in the whole organism at one dose (the size of the read-out at that dose, not a potency): 33%
Estimate against measurement, compound 4: 32 percentage points above; measured number inside the range.
By their numbers in this assay, from the lowest: compound 3; then compound 4; then compound 2; then compound 1.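

In this assay, 2-butoxycyclohexyl in place of 4-hydroxycyclohexyl on the amide-type nitrogen gives a partial recovery (a number 33 percentage points higher from compound 3 to compound 4 (beyond the scatter)), so an oxygen-bearing cyclohexyl at this place is compatible with a measurable read-out. The recovery stops well short of the unsubstituted cyclohexyl (a number 67 percentage points lower from compound 1 to compound 4 (beyond the scatter)), and the 2-butoxycyclohexyl group also falls modestly short of the 2-hydroxycycloheptyl group (a number 11 percentage points lower from compound 2 to compound 4 (beyond the scatter)), so all three oxygen-bearing groups stand below cyclohexyl, with butoxy on the ring giving no return to the level of compound 1. No measured evidence on hand accounts for these steps.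

The step to compound 4 changes the ring position of the oxygen and replaces the hydroxy with a butoxy chain together, and the two contributions cannot be separated from these compounds. A 2-hydroxycyclohexyl, a 2-methoxycyclohexyl or a 4-butoxycyclohexyl group would address that question, while an amine or a carboxylic acid on the same ring remains an open question at this place.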